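Hydroxyflavone ethers: swapping the terminal amine of compound 3

This account rests on a few compounds, and the source may have more. Where it says the series, first, only, none or still open, it means among the compounds named here.

Compound 3 `O=c1cc(-c2ccccc2)oc2cc(OCc3ccccc3)c(OCCCN3CCCC3)c(O)c12` has the lowest number of the two measured in a functional assay on HepG2 cells (Homo sapiens) for antiproliferative activity, read by MTT assay, with a stated time of 48 h; a lower number here means a stronger inhibitor, a higher number a weaker inhibitor; compound 3 gives 4200 nM. Compound 1 `CN1CCN(CCCCOc2c(O)cc3oc(-c4ccccc4)cc(=O)c3c2O)CC1` gives 93700 nM in this assay. Compound 2 `O=c1cc(-c2ccccc2)oc2cc(O)c(OCCCN3CCCC3)c(O)c12` is reported in this assay only as a limit, > 100000 nM, (the limit of > 100000 nM in this assay, at which 1 of the 3 values shown sits). The step of an at least 23-fold lower number from compound 2 to compound 3 (1.37 log units; beyond the scatter) is the large move in the set, and within it compound 3 stands apart from compound 1 by the margin noted above.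

Compound 4 `CN1CCN(CCCCOc2c(OCc3ccccc3)cc3oc(-c4ccccc4)cc(=O)c3c2O)CC1` is not yet measured. It differs from compound 3 in one place: (4-methylpiperazin-1-yl)methyl in place of pyrrolidin-1-yl on a saturated chain carbon, three bonds along the chain from an oxygen on an aromatic ring.

Among the compounds with values here, the one measured step that bears on this change is an at least 1.0-fold higher number from compound 1 to compound 2 (0.02 log units; that floor lies within the scatter), which runs the same exchange in the opposite direction, and its floor lies within the scatter; since compound 2 is a limit, the true size of that step is not known. Taken as the reverse of that step, the change into compound 4 is expected to give no movement beyond the scatter, with a slight lean toward a lower number.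

For compound 4 the expected value in this assay is 3500 nM, within 1200 nM to 11000 nM, an expected step of a 1.2-fold lower number from compound 3 to compound 4 (0.08 log units; within the scatter).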

Compound 4, half-maximal inhibitory concentration: 2500 nM
For compound 4 the middle estimate is 1.4-fold (0.15 log units) above the measured one; low and high end bracket the measured number.
By their numbers in this assay, from the lowest: compounds 4 and 3 (each within the scatter of the next); then compound 1. At a limit, above all of these: compound 2.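

In this assay, with the benzyl ether in place, the exchange of 3-(pyrrolidin-1-yl)propyl for 4-(4-methylpiperazin-1-yl)butyl gives a 1.7-fold lower number from compound 3 to compound 4 (0.23 log units; within the scatter) and so has a measured number at both ends, showing no movement beyond the scatter on this core. Set against the earlier pair, the exchange can be compared only loosely: the same change on two cores in this assay, an at least 1.0-fold higher number (0.02 log units; that floor lies within the scatter) from compound 1 to compound 2 and a 1.7-fold higher number (0.23 log units; within the scatter) from compound 4 to compound 3; the limit leaves it open whether they differ. The benzyl step also now has a measured number at both ends, with a 37-fold lower number from compound 1 to compound 4 (1.57 log units; beyond the scatter) on the 4-(4-methylpiperazin-1-yl)butyl side, and the large gain appears with both terminal amines: the same change on two cores in this assay, an at least 23-fold lower number (1.37 log units; beyond the scatter) from compound 2 to compound 3 and a 37-fold lower number (1.57 log units; beyond the scatter) from compound 1 to compound 4; the limit leaves it open whether they differ.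

Chain length and terminal amine change together in this exchange, leaving open how a terminal morpholine or dimethylamine, or a 4-(pyrrolidin-1-yl)butyl chain that separates the two changes, would read at this position. Also open, as far as these compounds go, is whether a smaller or different ether on the oxygen that carries the benzyl, such as methyl or a longer alkyl chain, would move the number as far as benzyl does.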